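This account rests on a few compounds, and the source may have more. Where it says the series, first, only, none or still open, it means among the compounds named here.

Compound 1 `CNc1nc(NC2(C#N)CCCCC2)nc(-n2cccn2)n1` and compound 2 `CNc1nc(NC2(C#N)CCCCC2)nc(SC)n1` share one core and differ in a single group on it. In an in vitro assay on Sf21 cells for inhibition of high affinity 3',5'-cyclic-AMP phosphodiesterase 7A (Homo sapiens) (a higher number here means a weaker inhibitor, a lower number a stronger inhibitor), compound 1 reaches only the limit of > 5000 nM, which is a limit of the assay and not a number. In this assay compound 2 gives 46 nM. Within the data shown here, the one measured step, an at least 100-fold lower number from compound 1 to compound 2 (2.03 log units; beyond the scatter), is large, and because compound 1 sits at the limit of > 5000 nM in this assay, at which 1 of the 2 values shown sits, its true size is known only as a floor.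

Compound 3 `CNc1nc(NC2(C#N)CCCCC2)nc(C2CC2)n1` is not yet measured. It differs from compound 1 as follows: cyclopropyl in place of 1H-pyrazol-1-yl on an aromatic carbon. Like the change that leads to compound 2, this removes the 1H-pyrazol-1-yl and puts a small group in its place. Among the measured compounds shown here, the only step that bears on it is an at least 100-fold lower number from compound 1 to compound 2 (2.03 log units; beyond the scatter). A large step down is therefore expected for compound 3 as well, though its size is uncertain, since a cyclopropyl is not a methylsulfanyl. For compound 3 in this assay the estimate is 150 nM, within a range from 20 nM to 1500 nM. Compound 3 is thus expected to show a step of an at least 33-fold lower number from compound 1 to compound 3 (1.52 log units; beyond the scatter).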

Compound 3, half-maximal inhibitory concentration: 539 nM
For compound 3 the middle estimate is 3.6-fold (0.56 log units) below the measured one, within the range that was stated.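

A second replacement of the 1H-pyrazol-1-yl on this aromatic carbon also lowers the number: cyclopropyl gives an at least 9.2-fold lower number from compound 1 to compound 3 (0.96 log units; beyond the scatter), so among these compounds the drop is not confined to methylsulfanyl. The true size of that step is known only as a floor, because compound 1 stands at a limit of the assay and not at a number: the limit of > 5000 nM in this assay, at which 1 of the 3 values shown sits. The two replacements do not serve equally, however, since exchanging methylsulfanyl for cyclopropyl gives a 12-fold higher number from compound 2 to compound 3 (1.07 log units; beyond the scatter), which shows that the choice of small group at this position still makes a large difference in this assay and that compound 2 remains the stronger inhibitor of the pair.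

Three compounds cannot tell whether the lower number of compound 2 belongs to its sulfur atom or to its open, unringed form. A methoxy group, an ethyl group or a dimethylamino group at the same place on the shared core would help to separate these two readings, and would show how far the trend among small groups extends.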